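A few compounds are considered here, and "the series" means these few. Any claim that something is new, unique, unknown or untested is made for them only; others in the source may bear on it.

Measured so far:
Compound 1 `Cc1cc(C(=O)O)ccc1CN1CCC[C@H](O[C@H](CO)c2cc(F)cc(F)c2)[C@@H]1c1ccccc1`: in an assay on isolated protein for activation of cGMP-dependent protein kinase 1 (Homo sapiens), read by ADP-Glo, with stated times of 30 min and 2 h (on this read-out higher numbers stand for an effect only at larger amounts of compound and lower numbers for an effect already at smaller amounts), compound 1 reaches only the limit > 200000 nM.
Compound 2 `Cc1cc(C(=O)O)ccc1CN1CCC[C@H](O[C@H](CF)c2cc(Cl)cc(Cl)c2)[C@@H]1c1ccccc1`: in this assay compound 2 gives 20000 nM.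
Compound 3 `Cc1cc(C(=O)O)ccc1CN1CCC[C@H](O[C@H](CO)c2ccnc(Cl)c2)[C@@H]1c1ccccc1`: in this assay compound 3 reaches only the limit > 200000 nM.

Compound 3 therefore stands at the limit, the point named in the limit of > 200000 nM in this assay, at which 2 of the 3 values shown sit, and compound 2 is the only one of the three with a number. Compound 4 `Cc1cc(C(=O)O)ccc1CN1CCC[C@H](OC(c2cc(Cl)cc(Cl)c2)C(C)O)[C@@H]1c1ccccc1` differs from compound 3 in one place: a group of 12 heavy atoms (9 carbon, 1 oxygen, 2 chlorine; one six-membered aromatic ring of carbon only) in place of a group of 10 heavy atoms (7 carbon, 1 nitrogen, 1 oxygen, 1 chlorine; one six-membered aromatic ring with 1 hetero atom), on an oxygen on a saturated carbon. Among the measured compounds shown here, the carbon-only ring with two chlorines is the one compound 2 carries, while the hydroxyl group on the chain recalls compound 1 and compound 3.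

For the measured compounds named here, two measured steps bear on this change. The step of an at least 10-fold lower number from compound 1 to compound 2 (1.00 log units; beyond the scatter) went with the dichlorophenyl and fluoromethyl pair, and the step of an at least 10-fold higher number from compound 2 to compound 3 (1.00 log units; beyond the scatter) undid it when that pair gave way to the chloropyridyl and hydroxymethyl pair. Going by the values given here, compound 4 joins the dichlorophenyl ring to a hydroxyl-bearing chain, a combination no measured compound shows, and both hydroxyl-bearing compounds sit at the limit.

Compound 4 is thus expected to fall below the limit of compound 3 by an at least 2.5-fold lower number from compound 3 to compound 4 (0.39 log units; beyond the scatter), yet stay short of compound 2. The estimate for compound 4 is 80000 nM, within 20000 nM to 200000 nM.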

Compound 4, half-maximal effective concentration: > 196000 nM
Compound 4: a limit, no number; the forecaster's own chance of this, stated with the estimate: 45%; middle value at least 2.4-fold (0.38 log units) away from the limit.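

In this assay compound 4 reaches only the limit > 196000 nM, which is a limit and not a number. Carrying the dichlorophenyl ring of compound 2 is therefore not enough for a measurable value at this position: with a hydroxyl-bearing chain in place of the fluoromethyl group there is an at least 9.8-fold higher number from compound 2 to compound 4 (0.99 log units; beyond the scatter). Among the compounds shown here, the steps from compound 1 and from compound 3 to compound 4 cannot be read, as both ends of each are limits, but compound 1, compound 3 and compound 4, the three compounds with a hydroxyl on the chain, now all stand at a limit, and compound 2, with its fluoromethyl group, remains the only one with a number.

The compounds shown do not separate the hydroxyl from the extra chain carbon or from the lack of a defined stereocentre in the group of compound 4, so it is unclear which of these goes with the higher number. As far as these compounds go, it also stays open how a dichlorophenyl group paired with a plain hydroxymethyl, methoxymethyl, difluoromethyl or aminomethyl chain would read in this assay.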